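A few compounds are considered here, and "the series" means these few. Any claim that something is new, unique, unknown or untested is made for them only; others in the source may bear on it.

In a functional assay on MGC-803 cells (Homo sapiens) for inhibition, read by MTT assay, with a stated time of 48 h (a lower number here means a stronger inhibitor, a higher number a weaker inhibitor), three members of one series have been measured. Compound 1 `C=C(C)C(=O)N(Cc1ccc(OC)c(O)c1)c1cc(OC)c(OC)c(OC)c1` gives 390 nM, compound 2 `COc1ccc(CN(C(=O)C[Se]C#N)c2cc(OC)c(OC)c(OC)c2)cc1O` gives 270 nM, and compound 3 `COc1ccc(CN(C(=O)CCCCCl)c2cc(OC)c(OC)c(OC)c2)cc1O` gives 540 nM. Compound 3 carries the highest of the three numbers, yet its steps to the other two both fall within the scatter: a 1.4-fold higher number from compound 1 to compound 3 (0.14 log units; within the scatter) and a 2.0-fold higher number from compound 2 to compound 3 (0.30 log units; within the scatter). The three numbers therefore cannot be ordered with confidence.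

Compound 4 `COc1ccc(CN(C(=O)/C=C/CBr)c2cc(OC)c(OC)c(OC)c2)cc1O` has not yet been measured. It differs from compound 3 at one place: 3-bromoprop-1-en-1-yl in place of 4-chlorobutyl on a carbonyl carbon. Among the compounds with values here, the steps that bear on this change are those altering the same carbonyl carbon or the chain bound to it, namely a 1.4-fold lower number from compound 1 to compound 2 (0.16 log units; within the scatter), a 1.4-fold higher number from compound 1 to compound 3 (0.14 log units; within the scatter) and a 2.0-fold higher number from compound 2 to compound 3 (0.30 log units; within the scatter), every one of them within the scatter. On that basis no step beyond the scatter is expected in this assay. The expected step is a 1.4-fold lower number from compound 3 to compound 4 (0.13 log units; within the scatter). Compound 4 is accordingly estimated to give about 400 nM, with a range from 180 nM to 900 nM.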

Compound 4, half-maximal inhibitory concentration: 71 nM
The estimate for compound 4 lay 5.6-fold (0.75 log units) above the measured number, outside the stated range (below it).
By their numbers in this assay, from the lowest: compound 4; then compounds 2, 1 and 3 (each within the scatter of the next).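

In this assay the group on this carbonyl carbon, whose earlier changes all stayed within the scatter, now moves the number beyond it: 3-bromoprop-1-en-1-yl in place of 4-chlorobutyl gives a 7.6-fold lower number from compound 3 to compound 4 (0.88 log units; beyond the scatter). The same group gives a 5.5-fold lower number from compound 1 to compound 4 (0.74 log units; beyond the scatter) in place of 1-methylethenyl and a 3.8-fold lower number from compound 2 to compound 4 (0.58 log units; beyond the scatter) in place of the selenium-bearing group, which makes compound 4 the most potent of the four. No measurement shown accounts for this gain.

Compound 4 differs from compound 3 in both the double bond and the bromine, and the compounds shown do not separate the two. Also open, going by these compounds, is what 3-chloroprop-1-en-1-yl would give, or an amine in place of the bromine.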